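This account rests on a few compounds, and the source may have more. Where it says the series, first, only, none or still open, it means among the compounds named here.

Compound 1 `COc1ccc(S(=O)(=O)Oc2ccccc2/C=C(\C#N)C(=O)Nc2nnc(Cc3cccc4ccccc34)s2)cc1`: 78%
Compound 2 `COc1ccc(S(=O)(=O)Oc2ccccc2/C=C(\C#N)C(=O)Nc2nnc(Cc3ccccc3)s2)cc1`: 78%
Compound 3 `N#C/C(=C\c1ccccc1OS(=O)(=O)c1ccc([N+](=O)[O-])cc1)C(=O)Nc1nnc(Cc2ccccc2)s1`: 57%

In a functional assay on RS4-11 cells (Homo sapiens) for inhibition, read by CCK-8 assay, with a stated time of 48 h, tested at 20 uM (on this read-out lower numbers stand for less inhibition of growth and higher numbers for more inhibition of growth at the one concentration tested), compound 2 gives 78%, level with compound 1 and clear of compound 3. Compound 4 `COc1ccc(S(=O)(=O)Oc2ccccc2/C=C(\C#N)C(=O)Nc2nnc(Cc3ccc(Cl)cc3)s2)cc1` keeps all of compound 2 except the benzyl group, which becomes 4-chlorobenzyl: chloro in place of hydrogen on an aromatic carbon. The closest evidence is the exchange of aromatic groups on that same chain carbon, no change at the digits printed from compound 1 to compound 2 (within the scatter). Swapping methoxy for nitro on a different ring gave a number 21 percentage points lower from compound 2 to compound 3 (beyond the scatter), so a single substituent can matter, but no chloro compound has been measured. No step beyond the scatter is therefore expected, and no direction can be favoured: a number 3 percentage points lower from compound 2 to compound 4 (within the scatter) is the expected step. For compound 4 the estimate is 75%, with an expected range of 60% to 88%.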

Compound 4, percent growth inhibition at one concentration: 77%
The estimate for compound 4 lay 2 percentage points below the measured number; measured number inside the range.
By their numbers in this assay, from the lowest: compound 3; then compounds 4, 1 and 2 (each within the scatter of the next).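

In this assay, going by these compounds alone, chloro in place of hydrogen gives a number 1 percentage points lower from compound 2 to compound 4 (within the scatter) and this is the first reading of a substituent on the benzyl ring, so this position accepts a chloro without a step beyond the scatter. Going the other way in size, 4-chlorophenyl in place of naphthalen-1-yl gives a number 1 percentage points lower from compound 1 to compound 4 (within the scatter) and so these groups on the chain carbon read alike. No measurement at hand explains this. On these data alone, whether an amine or a carboxylic acid at this position would read the same remains open.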